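The source may report more compounds than this note shows. Statements on the series, on what has been measured and on what is new or still open speak of the compounds shown alone.

Measured so far:
compound 1 `COC[C@@H]1CCCN1S(=O)(=O)c1ccc2c(c1)C(=O)C(=O)N2C` — > 500000 nM (a limit of the assay)
compound 2 `COC[C@@H]1CCCN1S(=O)(=O)c1ccc2c(c1)C(=O)C(=O)N2Cc1ccc(O[Si](C)(C)C(C)(C)C)cc1` — > 500000 nM (a limit of the assay)

Both of the values shown are limits rather than numbers. In an assay on isolated protein for inhibition of Caspase-8 (Homo sapiens) (a higher number here means a weaker inhibitor, a lower number a stronger inhibitor), compound 1 gives > 500000 nM, a limit. In this assay compound 2 gives > 500000 nM, likewise a limit. Compound 2 therefore stands at the limit of > 500000 nM in this assay, at which 2 of the 2 values shown sit, and no ranking between the two measured compounds can be drawn from it.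

Compound 3 `COC[C@@H]1CCCN1S(=O)(=O)c1ccc2c(c1)C(=O)C(=O)N2Cc1ccc(O)cc1` differs from compound 2 by a hydrogen atom in place of a group of 7 heavy atoms (6 carbon, 1 silicon; no ring), on an oxygen on an aromatic ring, so the protecting group on that oxygen is removed and a free phenol results. Within the data shown here, no step between two measured compounds exists, so the size of such a change cannot be read from any measured pair; with both measured values sitting at the same limit, the expected step of an at least 1.2-fold lower number from compound 2 to compound 3 (0.09 log units; that floor lies within the scatter) is none beyond the scatter, with the read-out most likely again returned as a limit. Compound 3 is accordingly expected to give about 400000 nM in this assay, with a range of 50000 nM to 2000000 nM.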

Compound 3, half-maximal inhibitory concentration: > 500000 nM
Compound 3: only a limit was reported; the forecaster's own chance of this, stated with the estimate: 75%; middle value at least 1.2-fold (0.09 log units) from the limit.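

In this assay compound 3 gives > 500000 nM, a limit. Compound 1 and compound 2 also stand at a limit, so the steps from each of them to compound 3 cannot be read: the limit of > 500000 nM in this assay, at which 3 of the 3 values shown sit. The compounds shown leave open how far any of the three lies beyond that limit, and whether either change alters the read-out at all.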